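This account rests on a few compounds, and the source may have more. Where it says the series, first, only, none or still open, it means among the compounds named here.

Measured so far in a functional assay on the whole organism (strain albino) for inhibition, with Rattus norvegicus as the target, read by paw edema, with stated times of 30 min and 1 h, at a dose of 5 mg/kg by the oral route; on this read-out lower numbers stand for less inhibition and higher numbers for more inhibition at the one dose given (going by the name of the read-out):
compound 1 `CCOC(=O)Cc1nc(N)n(C(=O)c2ccc(Br)cc2)n1` gives 34.8%
compound 2 `CCOC(=O)Cc1nc(N)n(C(=O)c2ccc(OC)cc2)n1` gives 32.8%
compound 3 `CCOC(=O)Cc1n[nH]c(NC(=O)c2ccc(Br)cc2)n1` gives 31.3%

Compound 1 and compound 2 share one core and differ in a single place, with methoxy in place of bromo on an aromatic carbon. On this change a number 2 percentage points lower from compound 1 to compound 2 (within the scatter), so the two values are not told apart by the measurement. Compound 3 carries the same atoms as compound 1 joined differently; the difference between the two cores is not broken down here. The three measured values all lie within the usual scatter of one another, so none of the three can be set above or below the others on this assay.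

Compound 4 `CCOC(=O)Cc1n[nH]c(NC(=O)c2ccc(OC)cc2)n1` has not yet been measured. It stands to compound 3 as compound 2 stands to compound 1, with methoxy in place of bromo on an aromatic carbon. The place of the change reads the same word for word in both pairs, so this is the same change made on the core of compound 3 instead of the core of compound 1. Among the measured compounds shown here, the only guide to its effect is the measured pair, and there the step was small. For the measured compounds named here, the step from compound 3 to compound 4 is therefore expected to be a number 1.8 percentage points lower from compound 3 to compound 4 (within the scatter), which rests on the one earlier instance of this change, where a number 2 percentage points lower from compound 1 to compound 2 (within the scatter). Going by the values given here, compound 4 is estimated at 29.5%, with a likely range from 20% to 39%; the estimate leans on only one prior step and carries the full scatter of the read-out.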

Compound 4, a percentage reported as inhibition, in the whole organism at one dose (the size of the read-out at that dose, not a potency): 30.2%
Compound 4: middle estimate off by 0.7 percentage points, on the low side, within the range that was stated.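

On the core of compound 3, in this assay, methoxy in place of bromo on an aromatic carbon gives a number 1.1 percentage points lower from compound 3 to compound 4 (within the scatter). Set beside the same change on the core of compound 1, the two steps cannot be told apart, so in these two cores the swap carries over as a step too small to read: the same change on two cores in this assay, a number 2 percentage points lower (within the scatter) from compound 1 to compound 2 and a number 1.1 percentage points lower (within the scatter) from compound 3 to compound 4, 0.9 percentage points apart, within the scatter of two such steps This shows only that neither core gives a measurable response to this one swap at the one dose given; it does not show that a step large enough to read would carry over in the same way, and it offers no basis for extending the result to cores beyond these two.

The compounds shown hold only bromo and methoxy at this place, on an aromatic carbon of a six-membered aromatic ring of carbon only, para to a large group, and all of them keep the ethyl ester. As far as these compounds go, whether an amine or a trifluoromethyl group at that place, or a carboxylic acid in place of the ethyl ester, would give a step beyond the scatter, and whether such a step would hold on both cores, remains open.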